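The compounds below may be only part of what the source reports. "The series", "measured", "known", "first", "only" and "open" are said of these compounds alone.

Measured so far:
compound 1, `OC[C@H](NC1CCN(CCCc2c[nH]c3ccc(-n4ccnc4)cc23)CC1)c1ccccc1`: 0.8 nM
compound 2, `COC[C@H](NC1CCN(CCCc2c[nH]c3ccc(-n4cnnc4)cc23)CC1)c1ccccc1`: 0.9 nM

In an assay on CHO cells for agonist activity at 5-hydroxytryptamine receptor 1D (Homo sapiens), read by GTPgammaS binding (a lower number here means that less compound is needed, a higher number that more compound is needed for the effect), compound 1 gives 0.8 nM and compound 2 gives 0.9 nM. Compound 2 carries the higher of the two numbers, but the gap to compound 1 lies within the usual scatter of repeated measurements, so the two compounds cannot be told apart on these values.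

The next compound is compound 3, `CC(CO)(NC1CCN(CCCc2c[nH]c3ccc(-n4cnnc4)cc23)CC1)c1ccccc1`. It is built from the same atoms as compound 2, joined differently: 1-(hydroxymethyl)-1-phenylethyl in place of 2-methoxy-1-phenylethyl on an amine nitrogen

Among the measured compounds shown here, no pair of measured compounds differs in just one place, so there is no measured step to lean on for this change. Both measured compounds sit close together, which gives no hint that the part being changed moves the number much. The expected step from compound 2 to compound 3 is a 2.2-fold higher number from compound 2 to compound 3 (0.35 log units; beyond the scatter), a small rise that may not exceed the scatter. Compound 3 is therefore estimated at 2 nM, with a likely range from 0.5 nM to 8 nM.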

Compound 3, half-maximal effective concentration: 3.4 nM
The estimate for compound 3 lay 1.7-fold (0.23 log units) below the measured number, within the range that was stated.
By their numbers in this assay, from the lowest: compounds 1 and 2 (each within the scatter of the next); then compound 3.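

In this assay, putting 1-(hydroxymethyl)-1-phenylethyl in place of 2-methoxy-1-phenylethyl on the amine nitrogen gives a 3.8-fold higher number from compound 2 to compound 3 (0.58 log units; beyond the scatter), so this position responds even when the same atoms are only joined differently. The swap keeps the count of heavy atoms and the phenyl ring, but it adds a hydrogen-bond donor and removes the defined stereocentre, so several things change at once. Nothing measured here explains the rise.

The compounds shown leave open which of these differences matters, since the hydroxyl group and the new branching arrive together. A 1-(methoxymethyl)-1-phenylethyl group on the same amine nitrogen would keep the branching without the hydroxyl group, and so could begin to separate the two.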